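A few compounds are considered here, and "the series" means these few. Any claim that something is new, unique, unknown or untested is made for them only; others in the source may bear on it.

Among the compounds with values here, in a functional assay on B16 cells (Mus musculus) for cytotoxicity, read by MTT assay, with a stated time of 48 h (a higher number here means a weaker inhibitor, a lower number a stronger inhibitor), compound 1 `C=C1CCC[C@]2(C)CCC(c3cn(-c4cccc([N+](=O)[O-])c4)nn3)=CC[C@@]12C` gives 31700 nM, the lower of the two numbers so far. Compound 2 `C=C1CCC[C@]2(C)CCC(c3cn(CC(=O)Nc4ccc(C)cc4)nn3)=CC[C@@]12C` gives 210000 nM, a higher number by a margin beyond the scatter. These two compounds differ in more than one place, so their gap cannot be tied to a single change.

The next compound is compound 3 `C=C1CCC[C@]2(C)CCC(c3cn(-c4ccc(C)cc4)nn3)=CC[C@@]12C`, with 4-methylphenyl in place of 3-nitrophenyl on an aromatic nitrogen of the five-membered aromatic ring with 3 nitrogen: 4-methylphenyl in place of 3-nitrophenyl on an aromatic nitrogen. Within the data shown here, no measured pair covers this change, so the direction rests on thin evidence. The expected step is a modest rise in the number, a 1.7-fold higher number from compound 1 to compound 3 (0.24 log units; within the scatter), which would put the central estimate inside the span of the two measured values. For compound 3 the estimated value is 55000 nM, with an expected range of 18000 nM to 160000 nM.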

Compound 3, half-maximal inhibitory concentration: 57600 nM
Compound 3: the middle estimate sits 1.0-fold (0.02 log units) below what was measured; low and high end bracket the measured number.
By their numbers in this assay, from the lowest: compounds 1 and 3 (each within the scatter of the next); then compound 2.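

In this assay, within the data shown here, 4-methylphenyl in place of 3-nitrophenyl on the aromatic nitrogen gives the first step that can be read in one place (a 1.8-fold higher number from compound 1 to compound 3 (0.26 log units; within the scatter)). At this position, then, the exchange costs nothing that can be told from the scatter, even though the nitro group leaves, a methyl group enters and the substituent sits elsewhere on the phenyl ring. No measured property bears on this step, and nothing shown accounts for it.

The compounds shown leave open whether the substituent or its place on the phenyl ring matters, since 3-methylphenyl and 4-nitrophenyl would be needed to separate the two. Also open, going by these compounds, is whether an amine or a carboxylic acid on that phenyl ring would give a step beyond the scatter.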